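Dialkylamino swap on the pyrimidine-fused core: compound 3

A few compounds are considered here, and "the series" means these few. Any claim that something is new, unique, unknown or untested is made for them only; others in the source may bear on it.

The series shares a core in which a phthalazinone-bearing benzamide is joined to a bicyclic amine, with the variable group sitting on an aromatic carbon between two ring nitrogen atoms. Compound 1 `O=C(c1cc(Cc2n[nH]c(=O)c3ccccc23)ccc1F)N1CCc2nc(N3CCCC3)ncc2C1` carries pyrrolidin-1-yl there and gives 7810 nM in a functional assay on HCC1937 cells (Homo sapiens) for inhibition, read by MTT assay, with a stated time of 48 h; on this read-out lower numbers stand for stronger inhibition and higher numbers for weaker inhibition. Compound 2 `CN(C)CCN(C)c1ncc2c(n1)CCN(C(=O)c1cc(Cc3n[nH]c(=O)c4ccccc34)ccc1F)C2` carries (2-(dimethylamino)ethyl)(methyl)amino instead; in this assay compound 2 reaches only a limit, > 200000 nM, and sits at the limit of > 200000 nM in this assay, at which 1 of the 2 values shown sits. Among the compounds with values here, the single measured step, an at least 25-fold higher number from compound 1 to compound 2 (1.40 log units; beyond the scatter), therefore runs from a measurable number to a limit.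

Compound 3 `CCN(CC)c1ncc2c(n1)CCN(C(=O)c1cc(Cc3n[nH]c(=O)c4ccccc34)ccc1F)C2` is the next case: diethylamino in place of (2-(dimethylamino)ethyl)(methyl)amino on an aromatic carbon, with the place unchanged. Diethylamino is an acyclic dialkylamino with no further nitrogen, so compound 3 stands nearer to compound 1 than to compound 2 in its variable group. Within the data shown here, the only step that bears on it is an at least 25-fold higher number from compound 1 to compound 2 (1.40 log units; beyond the scatter), and its reversal is the guide. The expected step is an at least 8.0-fold lower number from compound 2 to compound 3 (0.90 log units; beyond the scatter), a lower number in this assay, though the limit for compound 2 leaves its size uncertain. Compound 3 is expected at 25000 nM, with a range from 6000 nM to 150000 nM.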

Compound 3, half-maximal inhibitory concentration: 66800 nM
Compound 3: the middle estimate sits 2.7-fold (0.43 log units) below what was measured; the measured number falls inside the stated range.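

Diethylamino on the aromatic carbon between two ring nitrogen atoms returns a measurable number in this assay, so an acyclic dialkylamino at this place does not in itself push the series to the limit, and the change from the longer chain gives an at least 2.9-fold lower number from compound 2 to compound 3 (0.47 log units; beyond the scatter). Compound 2 remains a limit and not a number, so this step fixes only a minimum size: the limit of > 200000 nM in this assay, at which 1 of the 3 values shown sits. Diethylamino and pyrrolidin-1-yl are also not interchangeable here, as replacing the ring gives an 8.6-fold higher number from compound 1 to compound 3 (0.93 log units; beyond the scatter), and the three compounds therefore separate in the order pyrrolidin-1-yl, diethylamino, (2-(dimethylamino)ethyl)(methyl)amino, with the last known only as a limit.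

The compounds shown leave open whether the lower number of compound 1 belongs to a closed ring at this place or to pyrrolidin-1-yl alone, a question that piperidin-1-yl, morpholin-4-yl or azetidin-1-yl would bear on. They also leave open how far the number depends on the size of an acyclic group, which dimethylamino would test against diethylamino, and how much of the gap to compound 2 goes with the second nitrogen of its chain.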